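Swapping Methoxy for Phenyl in Two Related Cores

This account rests on a few compounds, and the source may have more. Where it says the series, first, only, none or still open, it means among the compounds named here.

Measured so far in a functional assay on HL-60 cells (Homo sapiens) for cytotoxicity, read by luminescence and CellTiter-Glo, with a stated time of 3 days; on this read-out lower numbers stand for stronger inhibition and higher numbers for weaker inhibition:
- compound 1 `COc1ccc(O)c(C(=O)Nc2ccc(C#N)cc2)c1` gives > 10000 nM, which is a limit of the assay rather than a number (the limit of > 10000 nM in this assay, at which 1 of the 3 values shown sits).
- compound 2 `N#Cc1ccc(NC(=O)c2cc(-c3ccccc3)ccc2O)cc1` gives 1350 nM.
- compound 3 `COc1ccc(C(=O)Nc2ccc(C#N)cc2)c(O)c1` gives 5470 nM.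

Compound 1 and compound 2 differ by one change, (phenyl in place of methoxy on an aromatic carbon), and the step was an at least 7.4-fold lower number from compound 1 to compound 2 (0.86 log units; beyond the scatter). Compound 3 is built from the same atoms as compound 1 joined differently; the difference between the two cores is not broken down here. Compound 4 `N#Cc1ccc(NC(=O)c2ccc(-c3ccccc3)cc2O)cc1` is not yet measured and differs from compound 3 by phenyl in place of methoxy on an aromatic carbon. This is the same kind of change as from compound 1 to compound 2, but the surroundings differ: in compound 1 the site is meta to a large group and para to a hydroxy group, whereas in compound 3 it is meta to a hydroxy group and para to a large group. Resting on the earlier step, compound 4 is expected to give 1000 nM in this assay, between 300 nM and 4000 nM, a step of a 5.5-fold lower number from compound 3 to compound 4 (0.74 log units; beyond the scatter).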

Compound 4, half-maximal inhibitory concentration: 700 nM
Estimate against measurement, compound 4: 1.4-fold (0.15 log units) above, within the range that was stated.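

In this assay, the step for phenyl in place of methoxy on the second core was a 7.8-fold lower number from compound 3 to compound 4 (0.89 log units; beyond the scatter). The change therefore lowered the number on both cores, and the two steps compare as follows: the same change on two cores in this assay, an at least 7.4-fold lower number (0.86 log units; beyond the scatter) from compound 1 to compound 2 and a 7.8-fold lower number (0.89 log units; beyond the scatter) from compound 3 to compound 4; the limit leaves it open whether they differ. Compound 1 gives > 10000 nM, which is a limit of the assay and not a number, so the size of the first step stays unfixed, and two cores do not show that the change would carry to a third.

The compounds shown leave open whether another group at this site, such as an amine or a carboxylic acid, would lower the number too. They also leave open whether the step comes from gaining phenyl or from losing methoxy.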